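This account rests on a few compounds, and the source may have more. Where it says the series, first, only, none or still open, it means among the compounds named here.

Series notes. The shared core of compound 1 `O=C1NCCC12CCN(c1c(Cl)cncc1-c1cccs1)CC2` carries a thiophen-2-yl on an aromatic carbon; in a functional assay on MV4-11 cells (Homo sapiens) for inhibition, read by resazurin assay, with a stated time of 72 h (on this read-out higher numbers stand for weaker inhibition of growth and lower numbers for stronger inhibition of growth), compound 1 gives 480 nM. Compound 2 `Cc1ccc(-c2cncc(Cl)c2N2CCC3(CCNC3=O)CC2)o1` bears a 5-methylfuran-2-yl in the same position and in this assay compound 2 gives 4950 nM. Compound 3 `O=Cc1ccc(-c2cncc(Cl)c2N2CCC3(CCNC3=O)CC2)o1` bears a 5-formylfuran-2-yl, and in this assay compound 3 gives 5190 nM. Among the three numbers compound 2 stands second highest: its neighbour is compound 3, within the scatter, while compound 1 lies far lower. The measured steps show that the five-membered ring itself is what moves the number: a 10-fold higher number from compound 1 to compound 2 (1.01 log units; beyond the scatter) and an 11-fold higher number from compound 1 to compound 3 (1.03 log units; beyond the scatter), whereas a 1.0-fold higher number from compound 2 to compound 3 (0.02 log units; within the scatter) shows that the substituent on the furan changes nothing beyond the scatter.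

Compound 4 `O=C1NCCC12CCN(c1c(Cl)cncc1-c1cn[nH]c1)CC2` differs from compound 2 as follows: 1H-pyrazol-4-yl in place of 5-methylfuran-2-yl on an aromatic carbon. This is again a swap of the whole five-membered ring, the kind of change that the two large steps from compound 1 show to be large; the direction for a pyrazole is not fixed by any measured pair. The expected outcome is a number somewhat lower than that of compound 2, with wide uncertainty. Compound 4 is therefore estimated at 1500 nM (range 300 nM to 7500 nM). That estimate corresponds to an expected step of a 3.3-fold lower number from compound 2 to compound 4 (0.52 log units; beyond the scatter).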

Compound 4, concentration for 50% growth inhibition: 8520 nM
For compound 4 the middle estimate is 5.7-fold (0.75 log units) below the measured one, and the stated range ends below it.
By their numbers in this assay, from the lowest: compound 1; then compounds 2, 3 and 4 (each within the scatter of the next).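

In this assay the pyrazole does not separate from the two furans at this position, despite its second ring nitrogen and its hydrogen-bond donor: a 1.7-fold higher number from compound 2 to compound 4 (0.24 log units; within the scatter), and a 1.6-fold higher number from compound 3 to compound 4 (0.22 log units; within the scatter). The thiophen-2-yl of compound 1 now stands apart from three replacements rather than two, with an 18-fold higher number from compound 1 to compound 4 (1.25 log units; beyond the scatter), so among the compounds shown, the large steps at this position follow the loss of thiophen-2-yl, and none of the three replacements goes against this, whether it has one ring hetero atom or two. Nothing shown explains why the thiophen-2-yl compound stands apart from the other three.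

On these data alone, it remains open whether the low number belongs to the thiophene ring specifically or would also appear with a plain phenyl or a pyridine at this position. As far as these compounds go, it is also open whether a methyl or formyl on the thiophene would leave the number of compound 1 intact, and whether a methyl in place of the pyrazole hydrogen would move the number of compound 4.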